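From Acetamido to 4-Carboxyphenyl in a Flat Series

This account rests on a few compounds, and the source may have more. Where it says the series, first, only, none or still open, it means among the compounds named here.

In a functional assay on MCF7 cells (Homo sapiens) for cytotoxicity, read by sulforhodamine B assay, with a stated time of 24 h (a lower number here means a stronger inhibitor, a higher number a weaker inhibitor), compound 1 `O=C1Nc2ccc(S(=O)(=O)N3CCOCC3)cc2/C1=N/c1ccc(Br)cc1` gives 44800 nM and compound 2 `Cc1ccc(/N=C2\C(=O)Nc3ccc(S(=O)(=O)N4CCOCC4)cc32)cc1` gives 55900 nM while compound 3 `CC(=O)N/N=C1\C(=O)Nc2ccc(S(=O)(=O)N3CCOCC3)cc21` gives 56000 nM so compound 3 stands level with the other two within the usual scatter.

The next structure, compound 4 `O=C1Nc2ccc(S(=O)(=O)N3CCOCC3)cc2/C1=N/c1ccc(C(=O)O)cc1`, carries 4-carboxyphenyl in place of acetamido on a double-bonded nitrogen.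

The closest measured steps run the opposite way, putting acetamido in place of 4-bromophenyl or 4-methylphenyl on that nitrogen. Both a 1.3-fold higher number from compound 1 to compound 3 (0.10 log units; within the scatter) and a 1.0-fold higher number from compound 2 to compound 3 (0.00 log units; within the scatter) stay within the scatter. Methyl in place of bromo, a 1.2-fold higher number from compound 1 to compound 2 (0.10 log units; within the scatter) also stays within it. Among the compounds with values here, no measured compound carries a carboxyl group, so that part of the change is untested.

Going by these small steps, no change beyond the scatter is expected in either direction, and the estimated step is a 1.1-fold lower number from compound 3 to compound 4 (0.05 log units; within the scatter) in size. Compound 4 is estimated in this assay at 50000 nM with 25000 nM to 100000 nM as its expected range.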

Compound 4, half-maximal inhibitory concentration: 26700 nM
Compound 4: the middle estimate sits 1.9-fold (0.27 log units) above what was measured; measured number inside the range.
By their numbers in this assay, from the lowest: compounds 4, 1, 2 and 3 (each within the scatter of the next, the first and the last beyond it).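

Carboxy is the first change in this series to move the number beyond the scatter, and it does so at the double-bonded nitrogen, where swapping acetamido for 4-carboxyphenyl in this assay gives a modest step (a 2.1-fold lower number from compound 3 to compound 4 (0.32 log units; beyond the scatter)). On the aromatic carbon, carboxy in place of methyl gives a step of the same modest size (a 2.1-fold lower number from compound 2 to compound 4 (0.32 log units; beyond the scatter)), yet carboxy in place of bromo stays within the scatter (a 1.7-fold lower number from compound 1 to compound 4 (0.22 log units; within the scatter)), so compound 1 goes against any general gain from carboxy. No measurement here offers a reason for these steps.

From the compounds shown here alone, whether the carboxyl group itself matters remains open, and a methyl ester or a primary amide on the same aromatic carbon could test this. Going by these compounds, how an amine there would compare with bromo, methyl and carboxy also remains open.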